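The compounds below may be only part of what the source reports. "The series", "measured", "known", "first", "only" and "open" are said of these compounds alone.

Compound 1 `O=C(c1ccccc1)N1CCCn2nc(COc3ccccc3)cc21` reaches, in a functional assay on HEK293 cells for positive allosteric modulation of metabotropic glutamate receptor 5 (Homo sapiens), read by calcium flux (a higher number here means a larger maximal response, a lower number a smaller maximal response), a largest response of 63%. Compound 2 `O=C(c1ccc(F)cc1)N1CCCn2nc(COc3ccccc3)cc21` carries one change from it, (fluoro in place of hydrogen on an aromatic carbon), and in this assay compound 2 gives 63%, so that no change at the digits printed from compound 1 to compound 2 (within the scatter). Compound 3 `CC(=O)N1CCCn2nc(COc3cccc(F)c3)cc21` has a different core; how its core differs from that of compound 1 is not broken down here. In this assay compound 3 gives 58%. Compound 4 `CC(=O)N1CCCn2nc(COc3cc(F)cc(F)c3)cc21` is not yet measured; it carries the same kind of change, (fluoro in place of hydrogen on an aromatic carbon), though here the place is meta to a fluoro group and meta to a large group, where the earlier one was para to a large group. The step from compound 3 to compound 4 is expected to be no change at the digits printed from compound 3 to compound 4 (within the scatter), resting on the first fluoro step, because no change at the digits printed from compound 1 to compound 2 (within the scatter). For compound 4 the estimated largest response is 58%, between 45% and 72%.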

Compound 4, largest response reached (reported as percent of maximum), in percent of the reference or control that the assay uses: 63%
Compound 4: middle estimate off by 5 percentage points, on the low side; the measured number falls inside the stated range.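

Swapping hydrogen for fluoro on an aromatic carbon gives, in this assay, a number 5 percentage points higher from compound 3 to compound 4 (within the scatter). The change therefore carries from one core to the other with no difference in step size that can be told from the scatter: the same change on two cores in this assay, no change at the digits printed (within the scatter) from compound 1 to compound 2 and a number 5 percentage points higher (within the scatter) from compound 3 to compound 4, 5 percentage points apart, within the scatter of two such steps

Within the data shown here, this agreement rests on only two pairs of compounds, with the fluoro at a different place on the ring in each pair, so it does not show that the swap would leave the largest response unchanged on other cores or at other places.

Among the compounds shown, these places hold only hydrogen or fluoro. From the compounds shown here alone, it remains open whether chloro, methoxy or an amine there would shift the largest response beyond the scatter.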